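This account rests on a few compounds, and the source may have more. Where it says the series, first, only, none or still open, it means among the compounds named here.

Measured so far in a functional assay on MV4-11 cells (Homo sapiens) for inhibition, read by resazurin assay, with a stated time of 72 h; on this read-out higher numbers stand for weaker inhibition of growth and lower numbers for stronger inhibition of growth:
compound 1 `O=C1NCCC12CCN(c1c(Cl)cncc1-c1ccoc1)CC2` gives 750 nM
compound 2 `O=Cc1ccc(-c2cncc(Cl)c2N2CCC3(CCNC3=O)CC2)s1` gives 750 nM
compound 3 `Cc1cc(-c2cncc(Cl)c2N2CCC3(CCNC3=O)CC2)sc1C=O` gives 2530 nM

Compound 1 stands level with compound 2 at the digits shown, the two together holding the lowest numbers of the three; compound 3 is the furthest from compound 1, with a 3.4-fold higher number from compound 1 to compound 3 (0.53 log units; beyond the scatter).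

Compound 4 `O=Cc1cc(-c2cncc(Cl)c2N2CCC3(CCNC3=O)CC2)co1` is not yet measured in this assay. Relative to compound 1 the change is formyl in place of hydrogen on an aromatic carbon, the formyl entering next to the ring oxygen.

Among the measured compounds shown here, two measured steps bear on this. The step of no change at the digits printed from compound 1 to compound 2 (within the scatter) replaces the whole furan by a thiophene already carrying a formyl and leaves the number where it was, within the scatter. The step of a 3.4-fold higher number from compound 2 to compound 3 (0.53 log units; beyond the scatter) shows that a further methyl on that formyl-bearing ring gives a modest rise. For the measured compounds named here, no measured pair isolates a formyl alone on the furan of compound 1, so the nearest guide remains the first of these steps, which read as no change.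

Compound 4 is therefore expected to sit close to compound 1, with a step of a 1.1-fold higher number from compound 1 to compound 4 (0.03 log units; within the scatter), that is, nothing beyond the scatter. The estimate for compound 4 is 800 nM, with a range of 350 nM to 1900 nM.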

Compound 4, concentration for 50% growth inhibition: 5150 nM
For compound 4 the middle estimate is 6.4-fold (0.81 log units) below the measured one, and the stated range ends below it.
By their numbers in this assay, from the lowest: compounds 1 and 2 (each within the scatter of the next); then compound 3; then compound 4.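

In this assay, among the compounds shown here, formyl in place of hydrogen on the furan carbon next to the ring oxygen gives a 6.9-fold higher number from compound 1 to compound 4 (0.84 log units; beyond the scatter), the first reading of this group alone on the furan of compound 1. The formyl-bearing ring matters at this place: 5-formylthiophen-2-yl showed no change at the digits printed from compound 1 to compound 2 (within the scatter), whereas exchanging it for 5-formylfuran-3-yl gives a 6.9-fold higher number from compound 2 to compound 4 (0.84 log units; beyond the scatter), and the exchange from 5-formyl-4-methylthiophen-2-yl still gives a 2.0-fold higher number from compound 3 to compound 4 (0.31 log units; beyond the scatter), so a formyl on the ring does not by itself fix the growth-inhibition read-out in this small set. Nothing measured here accounts for the gap between the formylfuran and the formylthiophene compounds.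

The compounds shown leave open whether the rise from compound 1 belongs to the formyl itself or would also follow a hydroxymethyl, a carboxylic acid or an aminomethyl on the same furan carbon. They also leave open how a plain thiophene without formyl would read against compound 1, so the contribution of the ring alone cannot be separated from that of the formyl it carries.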